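The source may report more compounds than this note shows. Statements on the series, on what has been measured and on what is new or still open speak of the compounds shown alone.

Measured so far:
- compound 1 `Cn1nnnc1SCC(=O)N/N=c1/scc(-c2ccc(Br)cc2)n1-c1ccccc1`: 19.3 ug/mL
- compound 2 `COc1ccc(-c2cs/c(=N/NC(=O)CSc3nnnn3C)n2-c2ccccc2)cc1`: 45 ug/mL

In an ADME assay on NIH3T3 cells (Mus musculus) for cytotoxicity, read by MTT assay, with a stated time of 24 h (on this read-out lower numbers stand for stronger inhibition and higher numbers for weaker inhibition), compound 1, at 19.3 ug/mL, holds the lower of the two numbers. Compound 3 `O=C(CSc1ncccn1)N/N=c1/scc(-c2ccc(Br)cc2)n1-c1ccccc1` keeps the core of compound 1 and changes the group on the sulfur: pyrimidin-2-yl in place of 1-methyl-1H-tetrazol-5-yl on a sulfur. Within the data shown here, the one measured step, a 2.3-fold higher number from compound 1 to compound 2 (0.37 log units; beyond the scatter), is modest and concerns another part of the molecule, so no measured step bears directly on this change. It serves only as a rough guide to size and gives no direction. The expected step is small, a 1.1-fold higher number from compound 1 to compound 3 (0.06 log units; within the scatter), and probably not beyond the scatter. Compound 3 is estimated at 22 ug/mL, with an expected range of 9 ug/mL to 52 ug/mL.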

Compound 3, half-maximal inhibitory concentration: 273 ug/mL
For compound 3 the middle estimate is 12-fold (1.09 log units) below the measured one; the whole stated range lies below it.
By their numbers in this assay, from the lowest: compound 1; then compound 2; then compound 3.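

In this assay the group on the sulfur turns out to be a sensitive point: pyrimidin-2-yl in place of 1-methyl-1H-tetrazol-5-yl gives a 14-fold higher number from compound 1 to compound 3 (1.15 log units; beyond the scatter) on an unchanged core, a large move towards weaker inhibition. Both groups have 6 heavy atoms, so the step comes with a change in ring size and hetero atoms, not in heavy-atom count. Nothing available accounts for this step.

Open, from the compounds shown here alone, is how a pyridin-2-yl or a plain methyl on that sulfur would read. Also open, going by these compounds, is whether the step holds with methoxy in place of bromo.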